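The compounds below may be only part of what the source reports. "The series", "measured", "known", "first", "only" and "open" are said of these compounds alone.

In a functional assay on MCF7 cells (Homo sapiens) for antiproliferative activity, read by sulforhodamine B assay, with a stated time of 48 h (on this read-out lower numbers stand for stronger inhibition and higher numbers for weaker inhibition), compound 1 `CCCN1CCN(c2ccc(S(=O)(=O)Oc3c(Cl)cc(Cl)cc3Cl)cc2)C1=O` reaches only a limit, > 100000 nM. Compound 2 `CCCN1CCN(c2ccc(S(=O)(=O)Oc3cc(OC)c(OC)c(OC)c3)cc2)C1=O` gives 49 nM. Compound 3 `CCCCN1CCN(c2ccc(S(=O)(=O)Oc3ccccc3)cc2)C1=O` gives 8800 nM, the higher of the two actual numbers, and its gap to compound 2 lies well beyond the usual scatter of repeated measurements.

Compound 4 `CCCCN1CCN(c2ccc(S(=O)(=O)Oc3cc(Br)cc(Br)c3)cc2)C1=O` has not yet been measured. It keeps the butyl chain of compound 3 and changes one group: 3,5-dibromophenyl in place of phenyl on an oxygen, with 3,5-dibromophenyl in place of phenyl on an oxygen whose other neighbour is the sulfonyl sulfur.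

For the measured compounds named here, no two measured compounds differ in just one place, so the guidance is loose. Compound 2, at 49 nM, shows that a group other than phenyl on this oxygen can go with a much lower number. Compound 1 goes against this pattern, offering only its limit.

A clear but uncertain improvement is therefore expected in this assay, with the estimated 5.9-fold lower number from compound 3 to compound 4 (0.77 log units; beyond the scatter) pointing to a lower number. For compound 4 the estimate is 1500 nM, with an expected range from 150 nM to 15000 nM.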

Compound 4, half-maximal inhibitory concentration: 58 nM
Beside the measured number, compound 4's estimate is 26-fold (1.41 log units) above it; measured number below the stated range.
By their numbers in this assay, from the lowest: compounds 2 and 4 (each within the scatter of the next); then compound 3. At a limit, above all of these: compound 1.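

In this assay, the group on the oxygen whose other neighbour is the sulfonyl sulfur proves to matter greatly: 3,5-dibromophenyl in place of phenyl gives a 150-fold lower number from compound 3 to compound 4 (2.18 log units; beyond the scatter). For the compounds shown here, this is the first step between compounds that differ in one place, so the effect of this change can be read directly, with the butyl chain and the rest of the core held the same. Nothing shown here gives a measured reason for the size of this step.

As far as these compounds go, it remains open whether a phenyl ring carrying a single bromine, or a 3,5-dichlorophenyl or 3,5-dimethoxyphenyl group, would act in the same way on this oxygen. From the compounds shown here alone, it is also open whether the same change would give a step of similar size on a compound with a propyl chain in place of the butyl chain.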